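Indole replacement on the piperidine carbon: compound 2 to compound 3

The source may report more compounds than this note shows. Statements on the series, on what has been measured and on what is new or still open speak of the compounds shown alone.

Compound 1 `COc1ccc2[nH]cc(C3CCN(CC(O)Cn4nc(-c5ccc(C(F)(F)F)cc5)c5c4CCN(S(C)(=O)=O)C5)CC3)c2c1` gives, in an assay on isolated protein for inhibition of cathepsin S (Homo sapiens) (a higher number here means a weaker inhibitor, a lower number a stronger inhibitor), 29 nM. Among the measured compounds shown here, compound 2 `CS(=O)(=O)N1CCc2c(c(-c3ccc(C(F)(F)F)cc3)nn2CC(O)CN2CCC(c3c[nH]c4c(Cl)cccc34)CC2)C1` gives in this assay 34 nM, the higher of the two numbers measured so far, with compound 1 the nearest; the step of a 1.2-fold higher number from compound 1 to compound 2 (0.07 log units; within the scatter) is the only one recorded, and it lies within the scatter. Compound 3 `CS(=O)(=O)N1CCc2c(c(-c3ccc(C(F)(F)F)cc3)nn2CC(O)CN2CCC(c3c[nH]c4cccnc34)CC2)C1` is not yet measured. It differs from compound 2 by a group of 9 heavy atoms (7 carbon, 2 nitrogen; one five-membered aromatic ring with 1 hetero atom, one six-membered aromatic ring with 1 hetero atom) in place of a group of 10 heavy atoms (8 carbon, 1 nitrogen, 1 chlorine; one five-membered aromatic ring with 1 hetero atom, one six-membered aromatic ring of carbon only), on a saturated ring carbon. For the measured compounds named here, the one measured step, a 1.2-fold higher number from compound 1 to compound 2 (0.07 log units; within the scatter), shows that exchanging one bicyclic group for another on this saturated ring carbon left the number in this assay essentially unchanged. On that basis no step beyond the scatter is expected for compound 3 in this assay, the expected step being a 1.2-fold higher number from compound 2 to compound 3 (0.07 log units; within the scatter). The estimate for compound 3 in this assay is 40 nM, within a range of 15 nM to 110 nM.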

Compound 3, half-maximal inhibitory concentration: 120 nM
Beside the measured number, compound 3's estimate is 3.0-fold (0.48 log units) below it; measured number outside the range, above it.
By their numbers in this assay, from the lowest: compounds 1 and 2 (each within the scatter of the next); then compound 3.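

In this assay the saturated ring carbon is not indifferent to the bicyclic group it carries: placing a hetero atom in the six-membered aromatic ring and removing the substituent give a 3.5-fold higher number from compound 2 to compound 3 (0.55 log units; beyond the scatter) against the 7-chloro-1H-indol-3-yl group and a 4.1-fold higher number from compound 1 to compound 3 (0.62 log units; beyond the scatter) against the 5-methoxy-1H-indol-3-yl group. The earlier exchange between these two carbon-only bicyclic groups stayed within the scatter, so the tolerance seen there does not extend to the group in compound 3. Nothing at hand explains this step.

The ring hetero atom and the missing substituent change together here, so their separate contributions remain unresolved. The unsubstituted 1H-indol-3-yl group, or a chlorine or methoxy group on the bicyclic group of compound 3, would separate the two.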